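From Nitro to Acetamido on a Shared Core

The source may report more compounds than this note shows. Statements on the series, on what has been measured and on what is new or still open speak of the compounds shown alone.

Of the compounds shown here, three have been read so far in an ADME assay on Vero cells (Chlorocebus sabaeus) for cytotoxicity (on this read-out lower numbers stand for higher toxicity in this test and higher numbers for lower toxicity in this test), and none of them has yielded an exact number. Compound 1 `O=[N+]([O-])c1ccc(-c2nc3ccccc3[nH]2)c([N+](=O)[O-])c1` gives > 100000 nM as a limit of the test. Compound 2 `COc1ccc(-c2nc3cc([N+](=O)[O-])ccc3[nH]2)c(OC)c1` gives > 100000 nM as a limit as well. Compound 3 `O=[N+]([O-])c1ccc(-c2nc3cc(Cl)c(Cl)cc3[nH]2)cc1` gives >= 100000 nM as a limit too, so its place on the scale is bounded and not fixed.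

Compound 4 `CC(=O)Nc1ccc(-c2nc3cc(Cl)c(Cl)cc3[nH]2)cc1` follows from compound 3 with acetamido in place of nitro on an aromatic carbon, para to a large group acetamido in place of nitro on an aromatic carbon and nothing else altered. Among the compounds with values here, no two measured compounds differ in one place only, so the size of such a change has not been observed. Within the data shown here, the only anchor is compound 3 with its limit of >= 100000 nM as the starting point. The estimated step of an at least 1.1-fold lower number from compound 3 to compound 4 (0.04 log units; that floor lies within the scatter) is expected to stay within the usual scatter, with no clear direction. Compound 4 is expected to give 90000 nM in this assay with an estimated range of 35000 nM to 200000 nM.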

Compound 4, half-maximal cytotoxic concentration: > 100000 nM
Compound 4 was reported as a limit (the forecaster's own chance of this, stated with the estimate: 65%); at least 1.1-fold (0.04 log units) between middle value and limit.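

Compound 3 and compound 4 are both reported only as limits in this assay, so no step can be read from acetamido in place of nitro. The compounds shown leave open where any of the four lies on the scale, and how large that change is.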